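Sulfone analogue with 3-(trifluoromethyl)phenyl: expected number

The source may report more compounds than this note shows. Statements on the series, on what has been measured and on what is new or still open speak of the compounds shown alone.

Compound 1 `CC(O)(CSc1ccc(F)cc1)C(=O)Nc1ccc(S(F)(F)(F)(F)F)cc1` is measured in a functional assay on LNCaP cells (Homo sapiens) for antiproliferative activity, read by propidium iodide staining, with a stated time of 96 h (on this read-out higher numbers stand for weaker inhibition and lower numbers for stronger inhibition), and gives 12500 nM. Compound 2 `CC(O)(CSc1cccc(C(F)(F)F)c1)C(=O)Nc1ccc(S(F)(F)(F)(F)F)cc1` carries the change 3-(trifluoromethyl)phenyl in place of 4-fluorophenyl on a sulfur and gives 18300 nM in this assay, so that a 1.5-fold higher number from compound 1 to compound 2 (0.17 log units; within the scatter). Compound 3 `CC(O)(CS(=O)(=O)c1ccc(F)cc1)C(=O)Nc1cccc(S(F)(F)(F)(F)F)c1` has a different core; the difference between the two cores is not broken down here. In this assay compound 3 gives 32600 nM, a number beyond the scatter above that of compound 1, while the gap to compound 2 stays within the scatter.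

Compound 4 `CC(O)(CS(=O)(=O)c1cccc(C(F)(F)F)c1)C(=O)Nc1cccc(S(F)(F)(F)(F)F)c1` is not yet measured. It differs from compound 3 by 3-(trifluoromethyl)phenyl in place of 4-fluorophenyl on a sulfonyl sulfur. This is the same kind of change as from compound 1 to compound 2, not the same: there the place was on a sulfur whose other neighbours are a saturated chain carbon, here it is on a sulfonyl sulfur whose other neighbours are a saturated chain carbon. Compound 4 is expected to show a 1.4-fold higher number from compound 3 to compound 4 (0.14 log units; within the scatter), because the earlier step was a 1.5-fold higher number from compound 1 to compound 2 (0.17 log units; within the scatter). Compound 4 is therefore estimated at 45000 nM, within 20000 nM to 100000 nM.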

Compound 4, half-maximal inhibitory concentration: 21800 nM
The estimate for compound 4 lay 2.1-fold (0.31 log units) above the measured number; the measured number falls inside the stated range.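

In this assay, putting 3-(trifluoromethyl)phenyl in place of 4-fluorophenyl on a sulfonyl sulfur gives a 1.5-fold lower number from compound 3 to compound 4 (0.17 log units; within the scatter). Set beside the same change on the core of compound 1, this step does not show that the core alters the outcome of the change: the same change on two cores in this assay, a 1.5-fold higher number (0.17 log units; within the scatter) from compound 1 to compound 2 and a 1.5-fold lower number (0.17 log units; within the scatter) from compound 3 to compound 4, 2.2-fold (0.34 log units) apart, within the scatter of two such steps Neither step stands clear of the scatter, so the two pairs are compatible with a change that makes little measurable difference on either core, but they do not show that its effect carries over, and the printed directions of the steps cannot be read as a true reversal.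

The compounds shown leave open whether a nitrile or a methoxy group on the aromatic ring attached to the sulfur would give a step beyond the scatter in this assay. What the difference between the two cores contributes on its own also stays open, as no two compounds shown differ only there.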